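A few compounds are considered here, and "the series" means these few. Any claim that something is new, unique, unknown or untested is made for them only; others in the source may bear on it.

Measured compounds in a functional assay on thoracic aorta (Rattus norvegicus, strain Wistar), with a stated time of 15 min; on this read-out higher numbers stand for an effect only at larger amounts of compound and lower numbers for an effect already at smaller amounts:

Compound 1, `CCOc1ccc(Cl)cc1C(C)NC(=O)N(C)S(=O)(=O)c1ccc(Cl)cc1`, gives 14600 nM.
Compound 2, `CCOc1ccc(Br)cc1C(C)NC(=O)N(C)S(=O)(=O)c1ccc(Cl)cc1`, gives 55700 nM.
Compound 3, `CCOc1ccc(Br)cc1C(C)NC(=O)NS(=O)(=O)c1ccccc1`, gives only a limit of the assay, > 300000 nM.

Compounds 1 and 2 share one core and differ in a single place: chloro in place of bromo on an aromatic carbon. That change lowered the number by a 3.8-fold lower number from compound 2 to compound 1 (0.58 log units; beyond the scatter). Compound 3 carries a different core; the difference between the two cores is not broken down here. For compound 3 the assay reports a limit and no number, a limit at which (the limit of > 300000 nM in this assay, at which 1 of the 3 values shown sits).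

Compound 4, `CCOc1ccc(Cl)cc1C(C)NC(=O)NS(=O)(=O)c1ccccc1`, has not yet been measured in this assay. It stands to compound 3 exactly as compound 1 stands to compound 2: chloro in place of bromo on an aromatic carbon. The two changes are the same, on the same kind of ring and in the same surroundings.

The expected step, resting on the measured pair in which compound 1 moved from compound 2 by a 3.8-fold lower number from compound 2 to compound 1 (0.58 log units; beyond the scatter), is an at least 2.5-fold lower number from compound 3 to compound 4 (0.39 log units; beyond the scatter). Because compound 3 itself is known only as the limit > 300000 nM, the starting point is uncertain, and a limit is again a real possibility for compound 4. Compound 4 is expected to give about 120000 nM in this assay. The estimated range for compound 4 runs from 30000 nM to 400000 nM.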

Compound 4, half-maximal effective concentration: > 300000 nM
Compound 4 ended at the assay's limit; the forecaster's own chance of this, stated with the estimate: 50%; middle value at least 2.5-fold (0.39 log units) away from the limit.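

Compound 3 and compound 4 both end at a limit of this assay rather than at a number, and no step between them can be read: the limit of > 300000 nM in this assay, at which 2 of the 4 values shown sit.

The compounds shown leave open whether chloro in place of bromo changes the number at all on the core of compound 3, as it does on the core of compound 1.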